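Solubility notes: phenoxy in place of trifluoromethylphenyl on the core

A few compounds are considered here, and "the series" means these few. Any claim that something is new, unique, unknown or untested is made for them only; others in the source may bear on it.

Measured in a physicochemical assay for solubility, with a stated time of 18 h, at pH 7.4; a lower number here means a less soluble compound, a higher number a more soluble compound:
compound 1 `COc1ccc(-c2ccc3c(NCCCNCc4cccc(OC)c4O)ccnc3c2)cc1` gives 32000 nM
compound 2 `FC(F)(F)c1ccc(-c2ccc3c(NCCCNCc4ccco4)ccnc3c2)cc1` gives 32000 nM
compound 3 `COc1cccc(CNCCCNc2ccnc3cc(CCC(C)C)ccc23)c1O` gives 4200 nM

Compound 2 stands level with compound 1 at the digits shown; the two cannot be ordered. Compound 3 gives the lower number of the set, and it is the compound furthest from compound 2.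

Going by the values given here, the only measured step that touches the position in question runs from compound 1 to compound 3: isopentyl in place of 4-methoxyphenyl on an aromatic carbon, with a 7.6-fold lower number from compound 1 to compound 3 (0.88 log units; beyond the scatter). Compound 4 `c1ccc(Oc2ccc3c(NCCCNCc4ccco4)ccnc3c2)cc1`, not yet measured, is made from compound 2 by phenoxy in place of 4-(trifluoromethyl)phenyl on an aromatic carbon.

Among the compounds with values here, the step to compound 4 keeps an aromatic six-membered ring at that carbon, unlike the step to compound 3, and there is no measured example of a phenoxy group here, so the step from compound 1 to compound 3 bears on it only loosely. Since compound 1 and compound 2 carry different aryl groups yet give the same number, the reading for compound 4 is expected to sit with them; the expected step is no change at the digits printed from compound 2 to compound 4 (within the scatter), none beyond the scatter. Compound 4 is estimated at 32000 nM, range 14000 nM to 70000 nM.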

Compound 4, solubility: 14500 nM
Compound 4: middle estimate off by 2.2-fold (0.34 log units), on the high side; measured number inside the range.
By their numbers in this assay, from the lowest: compound 3; then compound 4; then compounds 1 and 2 (each within the scatter of the next).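

In this assay, phenoxy in place of 4-(trifluoromethyl)phenyl gives a 2.2-fold lower number from compound 2 to compound 4 (0.34 log units; beyond the scatter) even though an aromatic six-membered ring of carbon only remains in the group at this carbon. The earlier step at the same carbon, a 7.6-fold lower number from compound 1 to compound 3 (0.88 log units; beyond the scatter), put isopentyl in place of 4-methoxyphenyl and so removed that ring; the new step shows that the number at this position can also move beyond the scatter with such a ring retained, though by a modest amount. The oxygen link and the loss of the trifluoromethyl group arrive together in this one step, and nothing measured here accounts for the lower number.

A plain phenyl or a 4-(trifluoromethyl)phenoxy group at this carbon would separate the contribution of the oxygen link from that of the trifluoromethyl group. Going by these compounds alone, it also remains open whether phenoxy gives a step of similar size with the side chain of compound 1 in place of the one shared by compound 2 and compound 4, and how an amine such as morpholine at this carbon would read.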